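Swapping Chloro for Methoxy Across Two Related Cores

The source may report more compounds than this note shows. Statements on the series, on what has been measured and on what is new or still open speak of the compounds shown alone.

Compound 1 `O=C(CBr)Nc1ccc(C(=O)/C=C/c2ccc(Cl)cc2)cc1` and compound 2 `COc1ccc(/C=C/C(=O)c2ccc(NC(=O)CBr)cc2)cc1` share one core, while compound 3 `C/C(=N/O)c1ccc(OCC(=O)Nc2ccc(C(=O)/C=C/c3ccc(Cl)cc3)cc2)cc1` and compound 4 `COc1ccc(/C=C/C(=O)c2ccc(NC(=O)COc3ccc(/C(C)=N\O)cc3)cc2)cc1` share another; the difference between the two cores is not broken down here. In a functional assay on the whole organism (strain albino) for inhibition, with Rattus norvegicus as the target, read by paw edema, with stated times of 30 min and 2 h, at a dose of 100 mg/kg by the oral route (on this read-out higher numbers stand for more inhibition at the one dose given (going by the name of the read-out) and lower numbers for less inhibition), compound 1 gives 52% and compound 2 gives 42%, the change methoxy in place of chloro on an aromatic carbon producing a step of a number 10 percentage points lower from compound 1 to compound 2 (within the scatter). In this assay compound 3 gives 54%, a number within the scatter of compound 1 and beyond it relative to compound 2. Compound 4 carries the same change on the second core, (methoxy in place of chloro on an aromatic carbon). That earlier step, a number 10 percentage points lower from compound 1 to compound 2 (within the scatter), lay within the scatter, so a like step is expected from compound 3 to compound 4, a number 10 percentage points lower from compound 3 to compound 4 (within the scatter). Compound 4 is accordingly estimated at 44%, between 34% and 56%.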

Compound 4, a percentage reported as inhibition, in the whole organism at one dose (the size of the read-out at that dose, not a potency): 41%
The estimate for compound 4 lay 3 percentage points above the measured number; the range from low to high includes it.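

Methoxy in place of chloro on the second core gives a number 13 percentage points lower from compound 3 to compound 4 (beyond the scatter), and this step does not differ in size from the one on the first core: the same change on two cores in this assay, a number 10 percentage points lower (within the scatter) from compound 1 to compound 2 and a number 13 percentage points lower (beyond the scatter) from compound 3 to compound 4, 3 percentage points apart, within the scatter of two such steps

In this assay, the change therefore carried from one core to the other in these two pairs, but this does not show that it would carry to any further core, nor does it explain the step. Where the larger group stands in place of one bromine atom, the result is a number 1 percentage points lower from compound 2 to compound 4 (within the scatter), so these two methoxy compounds stand within the scatter of each other.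

From the compounds shown here alone, it remains open whether a fluoro, an amine or a carboxylic acid in place of chloro would behave in the same way on both cores. Going by these compounds, how either change reads at other doses also remains open.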